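The compounds below may be only part of what the source reports. "The series", "measured", "known", "first", "only" and "open" are said of these compounds alone.

Measured so far:
Compound 1 `CCN(CC)C(=O)c1ccccc1OCC1=NCCN1` — in a functional assay for activation of Alpha-1D adrenergic receptor (Homo sapiens), read by calcium flux (on this read-out higher numbers stand for an effect only at larger amounts of compound and lower numbers for an effect already at smaller amounts), compound 1 gives < 5020 nM, which is a limit of the assay, not a number.
Compound 2 `c1ccc(-c2ccncc2)c(OCC2=NCCN2)c1` — in this assay compound 2 gives < 100000 nM, likewise only a limit.

Among the measured compounds shown here, compound 2 therefore stands at a limit, with no number to fix it, and compound 1 offers only a limit as well, so no measured step connects them. Compound 3 `c1csc(-c2ccccc2OCC2=NCCN2)c1` differs from compound 2 by thiophen-2-yl in place of pyridin-4-yl on an aromatic carbon. For the measured compounds named here, no measured step anchors this change, so the expectation rests on an assumed modest gain beyond the scatter. The step expected is a step that the limit leaves unreadable from compound 2 to compound 3. Compound 3 is estimated at 3000 nM, within 300 nM to 30000 nM.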

Compound 3, half-maximal effective concentration: 15.9 nM
For compound 3 the middle estimate is 190-fold (2.28 log units) above the measured one; measured number outside the range, below it.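

No step from compound 2 to compound 3 can be read, because compound 2 stands only at a limit of the assay, not at a number: the limit of < 100000 nM in this assay, at which 1 of the 3 values shown sits.

The compounds shown leave open how large the change is when thiophen-2-yl stands in place of pyridin-4-yl on an aromatic carbon.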